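The source may report more compounds than this note shows. Statements on the series, on what has been measured and on what is new or still open speak of the compounds shown alone.

In a functional assay on MCF7 cells (Homo sapiens) for antiproliferative activity, read by MTT assay, with a stated time of 72 h (on this read-out lower numbers stand for stronger inhibition and higher numbers for weaker inhibition), the compounds measured so far are:

compound 1 (`CC1=CC[C@H]2[C@H](CC[C@]2(C)O)C(C)(C)[C@@H]1CC[C@H]1[C@]2(C)CC[C@H](OC(=O)c3ccccc3)C(C)(C)O[C@H]2CC[C@@]1(C)O`) - 21000 nM
compound 2 (`CC1=CC[C@H]2[C@H](CC[C@]2(C)O)C(C)(C)[C@@H]1CC[C@H]1[C@]2(C)CC[C@H](OC(=O)c3ccc([N+](=O)[O-])cc3)C(C)(C)O[C@H]2CC[C@@]1(C)O`) - 21600 nM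
compound 3 (`CC1=CC[C@H]2[C@H](CC[C@]2(C)O)C(C)(C)[C@@H]1CC[C@H]1[C@]2(C)CC[C@H](OC(=O)c3ccc(C(F)(F)F)cc3)C(C)(C)O[C@H]2CC[C@@]1(C)O`) - 23400 nM

Compound 3 gives 23400 nM and so stands level with compound 1 and compound 2, within the scatter of both. The next change turns it into compound 4 (`CC1=CC[C@H]2[C@H](CC[C@]2(C)O)C(C)(C)[C@@H]1CC[C@H]1[C@]2(C)CC[C@H](OC(=O)c3ccccc3F)C(C)(C)O[C@H]2CC[C@@]1(C)O`), with 2-fluorophenyl in place of 4-(trifluoromethyl)phenyl on a carbonyl carbon.

Going by the values given here, three measured steps bear on this change. The first, a 1.0-fold higher number from compound 1 to compound 2 (0.01 log units; within the scatter), puts nitro in place of hydrogen on an aromatic carbon. The second, a 1.1-fold higher number from compound 1 to compound 3 (0.05 log units; within the scatter), puts trifluoromethyl there instead. The third, a 1.1-fold higher number from compound 2 to compound 3 (0.03 log units; within the scatter), exchanges these two groups. All three stayed within the scatter, so across these three compounds, none of which goes against the pattern, changing the aromatic group has made no measurable difference. Among the compounds with values here, no measured compound carries the 2-fluorophenyl group, however, so the data do not test it directly. A step beyond the scatter is therefore not expected in this assay in either direction.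

The expected step is a 1.1-fold lower number from compound 3 to compound 4 (0.03 log units; within the scatter) as an estimate only. For compound 4 the estimated value is 22000 nM with an expected range from 14000 nM to 35000 nM at the upper end.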

Compound 4, half-maximal inhibitory concentration: 11300 nM
Estimate against measurement, compound 4: 1.9-fold (0.29 log units) above; the whole stated range lies above it.
By their numbers in this assay, from the lowest: compounds 4, 1, 2 and 3 (each within the scatter of the next, the first and the last beyond it).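

In this assay, the aromatic group on this carbonyl carbon is not wholly without effect: swapping 4-(trifluoromethyl)phenyl for 2-fluorophenyl gives the only step among these compounds to pass beyond the scatter (a 2.1-fold lower number from compound 3 to compound 4 (0.32 log units; beyond the scatter)), though it is a modest one. Going by these compounds alone, that separation rests on this single pair, as the two other steps to the new compound stay within the scatter (a 1.9-fold lower number from compound 2 to compound 4 (0.28 log units; within the scatter); a 1.9-fold lower number from compound 1 to compound 4 (0.27 log units; within the scatter)), so the 2-fluorophenyl ester stands clearly apart only from the 4-(trifluoromethyl)phenyl ester, and compound 3 and compound 4 are the one pair that goes against the earlier picture of no measurable difference. Nothing available here accounts for this step.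

The compounds shown leave open how this position responds to groups that are not substituted phenyl rings, such as a cyclohexyl ring or a longer chain, and to an amine or a carboxylic acid on the aromatic ring. From the compounds shown here alone, whether the activity would survive a plain hydroxyl in place of the whole ester also remains open.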